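Trifluoromethyl for Fluoro: Cytotoxicity Across Two Cores

The compounds below may be only part of what the source reports. "The series", "measured", "known", "first", "only" and "open" are said of these compounds alone.

Measured so far:
Compound 1, `O=C(CCN1CCN(c2ccc(F)cc2)CC1)c1ccc(F)c(F)c1`: 385000 nM
Compound 2, `O=C(CCN1CCN(c2ccc(C(F)(F)F)cc2)CC1)c1ccc(F)c(F)c1`: 14000 nM
Compound 3, `O=C(CCN1CCN(c2ccc(F)cc2)CC1)c1ccc(OC(F)(F)F)cc1`: 70300 nM

All three compounds share a piperazine linked through a short chain to a ketone, with an aryl group at each end, and all were tested in an ADME assay on Vero cells (Chlorocebus sabaeus) for cytotoxicity, read by resazurin assay, with a stated time of 72 h; on this read-out lower numbers stand for stronger inhibition and higher numbers for weaker inhibition. Compound 1 and compound 2 differ in one place: trifluoromethyl in place of fluoro on an aromatic carbon. This single change gave a 28-fold lower number from compound 1 to compound 2 (1.44 log units; beyond the scatter), so compound 2 is far more cytotoxic than compound 1.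

Compound 3 carries a different aryl group on the ketone side; the difference between its core and that of compound 1 is not broken down here. In this assay compound 3 gives 70300 nM, a number that sits between those of compound 1 and compound 2.

Compound 4, `O=C(CCN1CCN(c2ccc(C(F)(F)F)cc2)CC1)c1ccc(OC(F)(F)F)cc1`, has not yet been measured. It stands to compound 3 as compound 2 stands to compound 1: trifluoromethyl in place of fluoro on an aromatic carbon. The place of the change is the same as before, so this is the same change on a different core. Compound 4 is expected to show a step of a 14-fold lower number from compound 3 to compound 4 (1.15 log units; beyond the scatter), resting on the step seen from compound 1 to compound 2, though a single prior example on another core gives only a rough guide. Compound 4 is therefore estimated at 5000 nM, with a plausible range from 1500 nM to 17000 nM.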

Compound 4, half-maximal inhibitory concentration: 64900 nM
For compound 4 the middle estimate is 13-fold (1.11 log units) below the measured one, outside the stated range (above it).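

In this assay, replacing fluoro with trifluoromethyl on the core of compound 3 gives a 1.1-fold lower number from compound 3 to compound 4 (0.03 log units; within the scatter), so the two compounds cannot be told apart on this read-out. Set beside the earlier result, the same change clearly behaves differently on the two cores: the same change on two cores in this assay, a 28-fold lower number (1.44 log units; beyond the scatter) from compound 1 to compound 2 and a 1.1-fold lower number (0.03 log units; within the scatter) from compound 3 to compound 4, 25-fold (1.40 log units) apart, beyond the scatter of two such steps. This shows that the large step seen on the core of compound 1 cannot simply be carried over to another core in this series, even when the change sits in the same place on the molecule, but it does not show which feature of the two cores is responsible or how the change would behave on a third core.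

The two cores differ in the aryl group on the ketone side, and the compounds shown leave open which part of that group decides whether the swap matters, for example whether a core carrying only a single fluoro or a methoxy group there would behave like the core of compound 1 or like that of compound 3. They also leave open how other groups in the same place on the aromatic ring, such as chloro, methyl or nitrile, would fare on each core.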